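A few compounds are considered here, and "the series" means these few. Any claim that something is new, unique, unknown or untested is made for them only; others in the source may bear on it.

Compound 1 `c1cn2cc(-c3ccsc3)nc(-c3ccc4ncn(C5CCCCC5)c4c3)c2n1` gives 30% in a functional assay on MOLT-4 cells (Homo sapiens) for inhibition, read by sulforhodamine B assay, with a stated time of 48 h, tested at 10 uM; on this read-out higher numbers stand for more inhibition at the one concentration tested (going by the name of the read-out) and lower numbers for less inhibition.
Compound 2 `Fc1ccccc1-c1cn2ccnc2c(-c2ccc3ncn(C4CCCCC4)c3c2)n1` gives 22.5% in this assay.

Among the measured compounds shown here, compound 2 stands at the lower of the two measured numbers in this assay, with compound 1 as its only neighbour; the one measured step, a number 7.5 percentage points lower from compound 1 to compound 2 (within the scatter), separates them and lies within the scatter, so the two compounds cannot be ordered against each other. Compound 3 `FC(F)(F)c1cccc(-c2cn3ccnc3c(-c3ccc4ncn(C5CCCCC5)c4c3)n2)c1` has not yet been measured. It differs from compound 2 by 3-(trifluoromethyl)phenyl in place of 2-fluorophenyl on an aromatic carbon, at the same aromatic carbon where the measured step exchanged the aryl group. That step is the only one that bears on this change, and it was small. For the measured compounds named here, no measured step involves a trifluoromethyl group at all, so the data give no direction for the new exchange. Compound 3 is therefore expected to sit close to compound 2, and the step of a number 0.5 percentage points lower from compound 2 to compound 3 (within the scatter) is estimated to stay within the scatter. Compound 3 is expected to give about 22% in this assay, with a range from 5% to 40%.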

Compound 3, a percentage reported as inhibition, at one concentration (the size of the read-out at that concentration, not a potency): 32.9%
Beside the measured number, compound 3's estimate is 10.9 percentage points below it; the measured number falls inside the stated range.
By their numbers in this assay, from the lowest: compounds 2, 1 and 3 (each within the scatter of the next, the first and the last beyond it).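

In this assay, among the compounds shown here, replacing 2-fluorophenyl with 3-(trifluoromethyl)phenyl on this aromatic carbon gives a number 10.4 percentage points higher from compound 2 to compound 3 (beyond the scatter) and so provides the first step at this position to pass beyond the scatter, showing that the aryl group here can move the number, if only modestly. Against thiophen-3-yl, the same group gives a number 2.9 percentage points higher from compound 1 to compound 3 (within the scatter) and leaves compound 1 and compound 3 unordered, so the only separation among the three compounds is that between compound 2 and compound 3, with compound 1 within the scatter of both. Nothing measured here accounts for the step between compound 2 and compound 3.

The two groups in that step differ both in the substituent and in where it sits on the phenyl ring, so the compounds shown cannot assign the step to either difference. From the compounds shown here alone, it also remains open how this position would respond to a plain phenyl group, or to a phenyl ring carrying an amine or a carboxylic acid.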